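Shifting the hydroxyl on a diaryl pyridine and cytotoxicity

The source may hold more compounds than are shown below. What is called first, only, known or untested is meant among the compounds shown, and "the series" means these compounds.

Measured compounds:
- compound 1, `Oc1cccc(-c2cc(-c3cccc(Cl)c3)nc(-c3ccccn3)c2)c1`: "not determined" (no result reported)
- compound 2, `Oc1cccc(-c2cc(-c3cccc(Cl)c3)nc(-c3ccco3)c2)c1`: 2530 nM

For the measured compounds named here, compound 2 is the only compound with a number in an ADME assay on HEK293 cells (Homo sapiens) for cytotoxicity, read by CCK-8 assay and cell counting, with a stated time of 2 days (a lower number here means a stronger inhibitor, a higher number a weaker inhibitor), where compound 2 gives 2530 nM. Compound 1 was tested in this assay, but for compound 1 the entry reads "not determined" (no result reported), so compound 2 stands alone and nothing can be said about its rank.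

Compound 3, `Oc1ccc(-c2cc(-c3cccc(Cl)c3)nc(-c3ccco3)c2)cc1`, is not yet measured. It differs from compound 2 in one place: 4-hydroxyphenyl in place of 3-hydroxyphenyl on an aromatic carbon. The two compounds have the same atoms, joined differently.

Going by the values given here, no step between measured compounds is available to guide the expectation. Moving a hydroxyl from one position of the phenyl ring to another is a small change, and the step from compound 2 to compound 3 in this assay is expected to be a 1.0-fold lower number from compound 2 to compound 3 (0.01 log units; within the scatter), that is, no change beyond the scatter in either direction. Compound 3 is therefore estimated at 2500 nM, with a range from 1000 nM to 6500 nM.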

Compound 3, half-maximal inhibitory concentration: 2880 nM
The estimate for compound 3 lay 1.2-fold (0.06 log units) below the measured number, and the stated range covers the measured number.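

In this assay, for the compounds shown here, putting 4-hydroxyphenyl in place of 3-hydroxyphenyl on the aromatic carbon opposite the ring nitrogen gives a 1.1-fold higher number from compound 2 to compound 3 (0.06 log units; within the scatter) and is the first step that can be read at this position. For this pair, with the 3-chlorophenyl and furan-2-yl groups held fixed, the hydroxyl can therefore occupy either place on the phenyl ring without a change beyond the scatter. No measurement at hand bears on this result.

Going by these compounds alone, compound 1 gives "not determined" (no result reported) in this assay and so offers no step that can be read. Still open, from the compounds shown here alone, is whether 2-hydroxyphenyl, or a methoxy group, an amine or a carboxylic acid in place of the hydroxyl, would move the number beyond the scatter.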